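A few compounds are considered here, and "the series" means these few. Any claim that something is new, unique, unknown or untested is made for them only; others in the source may bear on it.

Measured compounds:
compound 1 `COc1ccc2c(c1)OC(COc1ccc(CCC(=O)O)c(F)c1)CO2` 1470 nM
compound 2 `O=C(O)CCc1ccc(OCC2COc3ccc(Cl)cc3O2)cc1F` 830 nM
compound 3 `CC#CC(CC(=O)O)c1ccc(OCC2COc3ccc(Cl)cc3O2)cc1` 100 nM

In a functional assay on HEK293 cells for agonist activity at Free fatty acid receptor 1 (Homo sapiens), read by fluorescence and calcium flux, with a stated time of 10 min (on this read-out higher numbers stand for an effect only at larger amounts of compound and lower numbers for an effect already at smaller amounts), compound 3 gives the lowest of the three numbers; compound 2 gives a number higher by a margin beyond the scatter, and compound 1 a number higher still, also beyond the scatter. Among the compounds with values here, the only step between neighbours that differ in one place is a 1.8-fold lower number from compound 1 to compound 2 (0.25 log units; within the scatter), and it lies within the scatter. Within the data shown here, compound 3 differs from compound 2 in the chain that carries the acid and carries the prop-1-yn-1-yl group on a saturated chain carbon; no single step is recorded for this pair, so only its two values can be compared.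

Compound 4 `Cn1nncc1C(CC(=O)O)c1ccc(OCC2COc3ccc(Cl)cc3O2)cc1` is not yet measured. Its change against compound 3 is 1-methyl-1H-1,2,3-triazol-5-yl in place of prop-1-yn-1-yl on a saturated chain carbon bound to an aromatic carbon and a saturated chain carbon. Among the measured compounds shown here, none of the measured steps touches this position: the one recorded step concerns a substituent on the aromatic carbon of the shared core, which compound 3 and compound 4 share unchanged. There is therefore no measured basis for the direction or size of the step in this assay. The expectation for compound 4 is set near compound 3 with a wide range, a step of a 2.5-fold higher number from compound 3 to compound 4 (0.40 log units; beyond the scatter), and the estimated value for compound 4 is 250 nM, between 50 nM and 1200 nM.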

Compound 4, half-maximal effective concentration: 3870 nM
Compound 4: the middle estimate sits 15-fold (1.19 log units) below what was measured; measured number outside the range, above it.
By their numbers in this assay, from the lowest: compound 3; then compounds 2 and 1 (each within the scatter of the next); then compound 4.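

In this assay, the saturated chain carbon bound to an aromatic carbon and a saturated chain carbon proves highly sensitive to the group it carries: 1-methyl-1H-1,2,3-triazol-5-yl in place of prop-1-yn-1-yl gives a 39-fold higher number from compound 3 to compound 4 (1.59 log units; beyond the scatter). Within the data shown here, this is the first single-place step recorded at this position, and it stands well apart from the only earlier one, a 1.8-fold lower number from compound 1 to compound 2 (0.25 log units; within the scatter), which concerns a substituent on an aromatic carbon and lies within the scatter. The exchange replaces a ring-free group of 3 heavy atoms and 0 hydrogen-bond acceptors with an aromatic ring of 6 heavy atoms and 3 hydrogen-bond acceptors, and nothing at hand accounts for the step or separates these differences.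

Open, going by these compounds, is whether another group on this carbon, such as ethyl, cyclopropyl or phenyl, would keep the number close to that of compound 3 at 100 nM. Also open, on these data alone, is whether a 1-methyl-1H-1,2,3-triazol-5-yl group would give a step of similar size on a core carrying methoxy in place of chloro.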